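This account rests on a few compounds, and the source may have more. Where it says the series, first, only, none or still open, it means among the compounds named here.

Compound 1 `O=C(CCCCC(S)CCS)Nc1ccccc1`: 7.67%
Compound 2 `O=C(CCCCC(S)CCS)Nc1ccccc1Cl`: "not active" (no number reported)

Within the data shown here, in a functional assay on Bel-7402 cells (Homo sapiens) for inhibition, read by MTT assay, with a stated time of 24 h, tested at 100 ug/mL (on this read-out higher numbers stand for more inhibition of growth at the one concentration tested and lower numbers for less inhibition of growth), compound 1 gives 7.67%, and this is the only number available so far. Compound 2, which carries a chloro group on the aromatic ring, is recorded as "not active" (no number reported), so no number exists for it. Compound 1 therefore has no numerical neighbour to be ranked against.

The next compound to be tested is compound 3 `O=C(CCCCC(S)CCS)Nc1ccc(Cl)cc1`. It keeps the core of compound 1 and changes in one place: chloro in place of hydrogen on an aromatic carbon. In words, a chloro group takes the place of a hydrogen on an aromatic carbon, para to a large group.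

Among the measured compounds shown here, no measured pair shows what a single change of this kind does in this assay. For the measured compounds named here, the only number to build on is that of compound 1 at 7.67%, so no clear rise or fall can be predicted. The estimated step is a number 0.3 percentage points higher from compound 1 to compound 3 (within the scatter), which is expected to stay within the usual scatter. A result of no number at all also remains a realistic expectation. For compound 3 the expected value is 8%, with an estimated range from 0% to 20%.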

Compound 3, percent growth inhibition at one concentration: 25.5%
Compound 3: the middle estimate sits 17.5 percentage points below what was measured; measured number above the stated range.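

Putting a chloro group in place of a hydrogen on this aromatic carbon, para to a large group, gives a number 17.8 percentage points higher from compound 1 to compound 3 (beyond the scatter) in this assay. Among these compounds, this is the first single change with a size that can be read, and it shows that this position can respond to a small substitution on the ring of the core of compound 1. Compound 2 also carries a chloro group on the ring, but at a different carbon, and is recorded as "not active" (no number reported), so the two chloro compounds do not read alike, although the gap between them has no size; nothing measured here explains the effect of the chloro group at either carbon.

The compounds shown leave open whether it is chlorine itself that matters at this carbon, or whether fluorine, bromine, a methyl group, a methoxy group or an amine there would give a similar reading. They also leave open how compound 3 would behave across a range of concentrations, since its reading comes from a single concentration and gives no full measure of potency.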